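Swapping the aryl group on a urea acyl-CoA:cholesterol acyltransferase inhibitor

A few compounds are considered here, and "the series" means these few. Any claim that something is new, unique, unknown or untested is made for them only; others in the source may bear on it.

Two ureas have been measured in an assay on microsomes from intestine for inhibition of acyl-CoA:cholesterol acyltransferase (Oryctolagus cuniculus); a higher number here means a weaker inhibitor, a lower number a stronger inhibitor. Compound 1 `CC(C)c1cccc(C(C)C)c1NC(=O)NCc1ccccc1` gives 360 nM, while compound 2 `Cc1cccc(NC(=O)NCC2(c3ccccc3)CCCCC2)c1` gives 2800 nM. Compound 2 therefore stands at the higher of the two numbers, the weaker inhibitor of the pair, and its gap to compound 1 lies beyond the usual scatter of this assay.

Compound 3 `O=C(NCC1(c2ccccc2)CCCCC1)Nc1ccc(Cl)c(Cl)c1` has not yet been measured. It keeps the core of compound 2 and changes only one part: 3,4-dichlorophenyl in place of 3-methylphenyl on an amide-type nitrogen. Among the compounds with values here, nothing among the measured compounds shows how such a swap moves the readout, so no measured step can guide the estimate. The change adds two chlorine atoms in place of a methyl group on an otherwise unchanged ring, and the expectation here is a modest step toward a stronger inhibitor, of the size a 1.9-fold lower number from compound 2 to compound 3 (0.27 log units; within the scatter), with a fair chance that the step stays within the scatter. On this basis compound 3 is expected to give about 1500 nM in this assay, with a plausible range from 400 nM to 6000 nM.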

Compound 3, half-maximal inhibitory concentration: 3800 nM
Compound 3: the middle estimate sits 2.5-fold (0.40 log units) below what was measured; low and high end bracket the measured number.
By their numbers in this assay, from the lowest: compound 1; then compounds 2 and 3 (each within the scatter of the next).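

In this assay, within the data shown here, the swap to 3,4-dichlorophenyl in place of 3-methylphenyl on an amide-type nitrogen gives a 1.4-fold higher number from compound 2 to compound 3 (0.13 log units; within the scatter) and is the first change at this place that can be read on its own. Because that step lies within the scatter, the two aryl groups cannot be told apart in this read-out, so on this core, the data show no gain or loss from exchanging the methyl group for the two chlorine atoms. No measurement shown here says why the number behaves this way.

This single pair cannot show whether a group of a different kind on the same nitrogen, such as a phenyl ring carrying an amine or a carboxylic acid, would move the number beyond the scatter. On these data alone, compound 1 differs from compound 2 and compound 3 in more than one place, so those steps cannot be read, and it stays open which of its differences goes with its lower number.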